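A few compounds are considered here, and "the series" means these few. Any claim that something is new, unique, unknown or untested is made for them only; others in the source may bear on it.

Compound 1 `C=CCNc1nc(N)c(C(=O)N=C(N)N)nc1Cl` is measured in an assay for inhibition of acid-sensing ion channel 3 (Homo sapiens), read by patch clamp, tested at 20 uM; on this read-out lower numbers stand for less inhibition and higher numbers for more inhibition at the one concentration tested (going by the name of the read-out); in that assay compound 1 gives 78%, the lowest of the two numbers recorded there. Compound 2 `NC(N)=NC(=O)c1nc(Cl)c(NCc2ccc3ccccc3c2)nc1N` reaches 93% in this assay, a gap from compound 1 that lies beyond the usual scatter. Compound 3 `NC(N)=NC(=O)c1nc(Cl)c(NCC2CCc3ccccc3C2)nc1N` has no result in this assay; its entry for compound 3 reads "not determined" (no result reported). The compound that follows, compound 4 `NC(N)=NC(=O)c1nc(Cl)c(NC2CCCCC2)nc1N`, differs from compound 1 in one place: cyclohexyl in place of allyl on a nitrogen on an aromatic ring. Going by the values given here, no measured pair shows this particular change, so the size of the step is open; a larger group on that nitrogen is expected to hold or slightly raise inhibition, given that compound 2 gives 93%. Compound 4 is therefore estimated at 83%, with a range from 62% to 96%, a step expected as a number 5 percentage points higher from compound 1 to compound 4 (within the scatter).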

Compound 4, a percentage reported as inhibition, at one concentration (the size of the read-out at that concentration, not a potency): 92%
Compound 4: middle estimate off by 9 percentage points, on the low side; the range from low to high includes it.
By their numbers in this assay, from the lowest: compound 1; then compounds 4 and 2 (each within the scatter of the next).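

In this assay, going by these compounds alone, cyclohexyl in place of allyl on a nitrogen on an aromatic ring gives a number 14 percentage points higher from compound 1 to compound 4 (beyond the scatter) and is the first single change at this place that can be read. It shows that a six-membered non-aromatic carbon ring is accepted on this nitrogen and goes with more inhibition than allyl. No measurement given here accounts for the step. The compounds shown leave open whether a longer chain, or a cyclohexyl ring carrying a hydroxyl or an amine, would keep inhibition at this level. On these data alone, how compound 4 ranks in potency also stays open, with only one concentration tested.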